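Removing a Methoxy Group from a Growth Inhibitor

The source may hold more compounds than are shown below. What is called first, only, known or untested is meant among the compounds shown, and "the series" means these compounds.

Of the compounds shown here, two have so far been measured in a functional assay on CCRF-CEM cells (Homo sapiens) for inhibition, read by sulforhodamine B assay, with a stated time of 48 h, tested at 10 uM; on this read-out higher numbers stand for more inhibition of growth at the one concentration tested and lower numbers for less inhibition of growth. In this test, compound 1 `COc1ccc(-c2nc3sc(-c4ccccc4)cn3n2)cc1` gives 35%, the higher of the two numbers. Compound 2 `CC(=O)c1ccc(NC(=O)Cn2nc(C(F)(F)F)nc2N)cc1` gives 6.78%, and the gap between them lies beyond the usual scatter. Compound 1 therefore stands at the top of this short series, although its inhibition of growth at the single concentration tested is only partial.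

The next compound to be tested is compound 3 `c1ccc(-c2nc3sc(-c4ccccc4)cn3n2)cc1`, which keeps the core of compound 1 but has hydrogen in place of methoxy on an aromatic carbon, para to a large group (hydrogen in place of methoxy on an aromatic carbon). The two measured compounds do not form a single-place pair, so the data offer no direct guide to the size of such a step. The expectation therefore rests on compound 1 at 35%, its only measured close relative. The expected step of a number 7 percentage points lower from compound 1 to compound 3 (within the scatter) is a small fall in inhibition, probably not beyond the scatter. For compound 3, the estimated value is 28%, with an expected range from 10% to 50%.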

Compound 3, percent growth inhibition at one concentration: 13%
The estimate for compound 3 lay 15 percentage points above the measured number; low and high end bracket the measured number.
By their numbers in this assay, from the lowest: compounds 2 and 3 (each within the scatter of the next); then compound 1.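

In this assay, for the compounds shown here, hydrogen in place of methoxy on the aromatic carbon, para to a large group, provides the first comparison between two compounds that differ in one place only, and the change is a number 22 percentage points lower from compound 1 to compound 3 (beyond the scatter). With the rest of the core of compound 1 kept, this position is therefore not indifferent to what it carries, and the methoxy group goes with a level of growth inhibition that hydrogen does not match. The data at hand offer no measurement that would explain this difference, so the step stands as an observation on a single pair.

On these data alone, it remains open whether this effect belongs to the oxygen, to the methyl carbon or simply to the presence of some group at this place, a question that a hydroxyl group, a fluorine atom, an ethoxy group or an amine at the same carbon would begin to answer. As far as these compounds go, it also remains open whether the same change would produce a step of similar size on the other aromatic ring or on a different core.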